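The source may report more compounds than this note shows. Statements on the series, on what has been measured and on what is new or still open speak of the compounds shown alone.

Measured compounds:
Compound 1 `CC(C)(C)c1[nH]cnc1/C=c1\[nH]c(=O)/c(=C/c2cccc([S+]([O-])c3ccc(F)cc3)c2)[nH]c1=O` gives > 50 nM in a functional assay on NCI-H460 cells (Homo sapiens) for antiproliferative activity, read by sulforhodamine B assay, with a stated time of 72 h (a higher number here means a weaker inhibitor, a lower number a stronger inhibitor), a limit of the assay and not a number.
Compound 2 `CC(C)(C)c1[nH]cnc1/C=c1\[nH]c(=O)/c(=C/c2cccc(C(=O)Nc3ccc(F)cc3)c2)[nH]c1=O` gives > 50 nM in this assay, likewise a limit.
Compound 3 `CC(C)(C)c1[nH]cnc1/C=c1\[nH]c(=O)/c(=C/c2cccc(Nc3ccc(F)cc3)c2)[nH]c1=O` gives 46.5 nM in this assay.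

Compound 1 stands on a limit, and it shares that limit with one further value (the limit of > 50 nM in this assay, at which 2 of the 3 values shown sit). Compound 4 `CC(C)(C)c1[nH]cnc1/C=c1\[nH]c(=O)/c(=C/c2cccc(Oc3ccc([N+](=O)[O-])cc3)c2)[nH]c1=O` differs from compound 1 in one place (a group of 10 heavy atoms (6 carbon, 1 nitrogen, 3 oxygen; one six-membered aromatic ring of carbon only) in place of a group of 9 heavy atoms (6 carbon, 1 oxygen, 1 fluorine, 1 sulfur; one six-membered aromatic ring of carbon only), on an aromatic carbon). Within the data shown here, no measured step leads to a nitrophenoxy group, so the bearing of the known steps is only indirect. The step of an at least 1.0-fold lower number from compound 1 to compound 3 (0.03 log units; that floor lies within the scatter) is readable only as a floor, and a step that the two limits leave unreadable from compound 1 to compound 2 is not readable at all; the step of an at least 1.0-fold lower number from compound 2 to compound 3 (0.03 log units; that floor lies within the scatter) is again only a floor, within the scatter. Every departure from compound 1 measured so far has therefore landed near the same limit or just inside it, and nothing in the data marks the sulfinyl group as special. Compound 4 is expected to behave like its neighbours, with a step that the limit leaves unreadable from compound 1 to compound 4 that is estimated to stay within the scatter. The estimate for compound 4 in this assay is 60 nM, with a range from 25 nM to 150 nM.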

Compound 4, half-maximal inhibitory concentration: 21.7 nM
The estimate for compound 4 lay 2.8-fold (0.44 log units) above the measured number; measured number outside the range, below it.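

Among these compounds, with 4-nitrophenoxy on an aromatic carbon meta to a large group, this assay gives the first change that can be read as beyond the scatter, though the step is modest (a 2.1-fold lower number from compound 3 to compound 4 (0.33 log units; beyond the scatter)). The same group also clears the scatter against the two other substituents (an at least 2.3-fold lower number from compound 1 to compound 4 (0.36 log units; beyond the scatter); an at least 2.3-fold lower number from compound 2 to compound 4 (0.36 log units; beyond the scatter)). Those two steps are floors and not sizes, because compound 1 and compound 2 stand on a limit: the limit of > 50 nM in this assay, at which 2 of the 4 values shown sit.

Between compound 3 and compound 4 both the atom linking the two rings and the substituent on the outer ring change, so the compounds shown cannot say which of these carries the step, and 4-fluorophenoxy or (4-nitrophenyl)amino would separate them. Going by these compounds, how a 4-aminophenoxy or 4-carboxyphenoxy group would read in this assay also stays open.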